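A few compounds are considered here, and "the series" means these few. Any claim that something is new, unique, unknown or untested is made for them only; others in the source may bear on it.

In a functional assay on the whole organism for positive allosteric modulation, with Mus musculus as the target (a higher number here means that more compound is needed for the effect, a lower number that less compound is needed), compound 1 (`CCC(=O)N(c1ccc(C)cc1)C1CCCC1N(C)C`) gives 10 mg/kg; 10 mg/kg (2 entries). Compound 2 (`CCC(=O)N(c1ccc(Br)cc1)C1CCCC1N(C)C`) is recorded only as a limit, > 50 mg/kg, so no exact number is available for it. Compound 3 (`CCC(=O)N(c1ccc(C(F)(F)F)cc1)C1CCCC1N(C)C`) has trifluoromethyl in place of bromo on an aromatic carbon, para to a large group (trifluoromethyl in place of bromo on an aromatic carbon). Within the data shown here, no measured pair sizes this exchange. In this assay, no shift in either direction beyond the usual scatter is expected, giving an estimated a number no higher from compound 2 to compound 3 (the limit leaves the size open). Compound 3 is expected at 50 mg/kg, with an estimated range of 15 mg/kg to 150 mg/kg.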

Compound 3, dose for half-maximal effect: 10 mg/kg
Beside the measured number, compound 3's estimate is 5.0-fold (0.70 log units) above it; the whole stated range lies above it.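

In this assay, trifluoromethyl in place of bromo, on the aromatic carbon para to a large group, goes with an at least 5.0-fold lower number from compound 2 to compound 3 (0.69 log units; beyond the scatter), so the number at this position depends on the group placed there. Compound 3 gives 10 mg/kg and compound 1 gives 10 mg/kg; 10 mg/kg (2 entries), the same printed value with trifluoromethyl and with methyl. The step remains open at one end, as the entry for compound 2 is a limit: the limit of > 50 mg/kg in this assay, at which 1 of the 3 values shown sits.

From the compounds shown here alone, what a nitrile, a methoxy group or an amine at this position would give in this assay stays open, as does the effect of a longer chain on the carbonyl.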